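A few compounds are considered here, and "the series" means these few. Any claim that something is new, unique, unknown or untested is made for them only; others in the source may bear on it.

Working notes on the series, read in a functional assay on DU-145 cells (Homo sapiens) for inhibition, read by trypan blue exclusion, with a stated time of 96 h; a higher number here means a weaker inhibitor of growth, a lower number a stronger inhibitor of growth. Among the measured compounds shown here, compound 1 `Cc1ccc(CS/C(=C/c2c(O)cc(O)cc2O)C(=O)c2ccc(Cl)cc2)cc1` gives 50000 nM as the only true number in the set. For compound 2 `O=C(/C(=C\c1c(O)cc(O)cc1O)SCc1ccc(Cl)cc1)c1ccc(Cl)cc1` the entry > 100000 nM is a limit. For compound 3 `Cc1ccc(S/C(=C/c2c(O)cc(O)cc2O)C(=O)c2ccc(Cl)cc2)cc1` the entry > 100000 nM is also a limit. Compound 3 therefore stands at the limit of > 100000 nM in this assay, at which 2 of the 3 values shown sit, and has no number of its own.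

Compound 4 `O=C(/C(=C\c1c(O)cc(O)cc1O)SCc1ccc(Cl)c(Cl)c1)c1ccc(Cl)cc1` follows from compound 3 by this change: 3,4-dichlorobenzyl in place of 4-methylphenyl on a sulfur.

For the measured compounds named here, three measured steps bear on it. The nearest is an at least 2.0-fold higher number from compound 1 to compound 3 (0.30 log units; that floor lies within the scatter), an exchange on the sulfur that runs opposite to the one here and whose floor stays within the scatter. Chlorine enters in an at least 2.0-fold higher number from compound 1 to compound 2 (0.30 log units; that floor lies within the scatter), again with a floor within the scatter and with no gain in growth inhibition shown. The step that the two limits leave unreadable from compound 2 to compound 3 gives no size at all.

Going by the values given here, a benzyl on the sulfur carries the one number, in compound 1 at 50000 nM, so only a small move to a lower number is expected, and it may not clear the scatter. The expected step is an at least 1.4-fold lower number from compound 3 to compound 4 (0.15 log units; that floor lies within the scatter) in this assay and remains a rough estimate. Compound 4 is estimated at 70000 nM with 25000 nM to 200000 nM as the expected range.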

Compound 4, concentration for 50% growth inhibition: 25000 nM
The estimate for compound 4 lay 2.8-fold (0.45 log units) above the measured number; measured number inside the range.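

In this assay, among the compounds shown here, 3,4-dichlorobenzyl on the sulfur gives the first steps that clear the scatter: an at least 4.0-fold lower number from compound 3 to compound 4 (0.60 log units; beyond the scatter) and an at least 4.0-fold lower number from compound 2 to compound 4 (0.60 log units; beyond the scatter), the latter from added chloro on the benzyl ring alone. Both steps are floors, not exact sizes, since compound 2 and compound 3 each have only a limit and no number of their own: the limit of > 100000 nM in this assay, at which 2 of the 4 values shown sit. The step to the other compound with a true number, a 2.0-fold lower number from compound 1 to compound 4 (0.30 log units; within the scatter), stays within the scatter, so compound 1 and compound 4 cannot be ordered, and the gain over compound 2 does not set 3,4-dichlorobenzyl apart from the 4-methylbenzyl of compound 1.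

The compounds shown leave open whether a benzyl ring bearing an amine or a carboxylic acid in place of chloro would keep a measurable number in this assay, and whether a longer chain between the sulfur and the ring would do so. For the compounds shown here, they also leave open whether the two chloro groups of compound 4 each contribute on their own, as no compound carries a single chloro at the other ring position.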